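Lengthening a Chain on the Shared Core

The compounds below may be only part of what the source reports. "The series", "measured", "known", "first", "only" and "open" are said of these compounds alone.

Compound 1 `COc1cc(OC)c(C(=O)/C=C/c2cccc(N3CCNCC3)c2)c(O)c1C` was measured in an ADME assay on MCF7-DOX cells (Homo sapiens) for cytotoxicity, read by MTT assay, with a stated time of 48 h (a lower number here means a stronger inhibitor, a higher number a weaker inhibitor), and gave 98700 nM. Its number stands above that of compound 2 `COc1cc(OC)c(C(=O)/C=C/c2cccc(F)c2)c(O)c1CC=C(C)C`, which gave 45400 nM, a gap beyond the scatter, while compound 3 `COc1cc(OC)c(C(=O)/C=C/c2ccc(N3CCNCC3)cc2)c(O)c1CC=C(C)C` gave 57800 nM, a number within the scatter of compound 1. Compound 4 `CCCc1c(OC)cc(OC)c(C(=O)/C=C/c2cccc(N3CCNCC3)c2)c1O` has not yet been measured. It differs from compound 1 by ethyl in place of hydrogen on a saturated chain carbon bound to an aromatic carbon. Within the data shown here, no step between measured compounds isolates such a change, so its effect here is unknown. All three measured numbers lie close together, which argues for a modest move at most. The step of a 1.4-fold lower number from compound 1 to compound 4 (0.15 log units; within the scatter) is expected to be small and downward, possibly not beyond the scatter. Compound 4 is estimated to give 70000 nM, within a range from 30000 nM to 160000 nM.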

Compound 4, half-maximal inhibitory concentration: > 100000 nM
Compound 4 gave a limit, no number; the forecaster's own chance of this, stated with the estimate: 10%; middle value at least 1.4-fold (0.15 log units) away from the limit.
By their numbers in this assay, from the lowest: compounds 2, 3 and 1 (each within the scatter of the next, the first and the last beyond it). At a limit, above all of these: compound 4.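

In this assay compound 4 gives > 100000 nM, which is a limit and not a number. Ethyl in place of hydrogen on a saturated chain carbon bound to an aromatic carbon, the same difference as methyl to propyl, thus gives no sign of a stronger inhibitor, with a step of an at least 1.0-fold higher number from compound 1 to compound 4 (0.00 log units; that floor lies within the scatter), and the true size of that step cannot be read. This reading rests on a single value at the limit: the limit of > 100000 nM in this assay, at which 1 of the 4 values shown sits.

Still open, going by these compounds, is what an ethyl chain, one carbon shorter than the propyl of compound 4, would give on the shared core. On these data alone, a propyl chain ending in an amine or a carboxylic acid is equally open.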